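Swapping a Pyridine for a Hydroxypiperidine on the Sulfonyl Sulfur

The source may report more compounds than this note shows. Statements on the series, on what has been measured and on what is new or still open speak of the compounds shown alone.

Of the compounds shown here, three sharing one core have been tested in a functional assay on A2780 cells (Homo sapiens) for cytotoxicity, read by sulforhodamine B assay, with a stated time of 72 h; a higher number here means a weaker inhibitor, a lower number a stronger inhibitor. Compound 1 `O=C(NCc1ccc(S(=O)(=O)c2cncc(C(F)(F)F)c2)cc1)N1Cc2ccncc2C1` gives 10 nM. Compound 2 `O=C(NCc1ccc(S(=O)(=O)C2CCN(C3COC3)CC2)cc1)N1Cc2ccncc2C1` gives 7.4 nM, and compound 3 `O=C(NCc1ccc(S(=O)(=O)N2CCOCC2)cc1)N1Cc2ccncc2C1` gives 68 nM. Compound 1 therefore sits second highest of the three, close to compound 2, since the step of a 1.4-fold lower number from compound 1 to compound 2 (0.13 log units; within the scatter) stays within the scatter, while the step of a 6.8-fold higher number from compound 1 to compound 3 (0.83 log units; beyond the scatter) sets compound 3 apart as the weaker inhibitor.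

The unmeasured compound 4 `O=C(NCc1ccc(S(=O)(=O)N2CCC[C@H](O)C2)cc1)N1Cc2ccncc2C1` differs from compound 1 in one place: 3-hydroxypiperidin-1-yl in place of 5-(trifluoromethyl)pyridin-3-yl on a sulfonyl sulfur.

Within the data shown here, of the measured steps, the one to compound 3 bears most on this change, because a 6.8-fold higher number from compound 1 to compound 3 (0.83 log units; beyond the scatter) also replaces the 5-(trifluoromethyl)pyridin-3-yl with a six-membered non-aromatic ring on the sulfonyl sulfur, and morpholin-4-yl resembles 3-hydroxypiperidin-1-yl by name more closely than the 1-(oxetan-3-yl)piperidin-4-yl of compound 2 does. The step of a 9.2-fold higher number from compound 2 to compound 3 (0.96 log units; beyond the scatter) points the same way. A modest rise in the number, beyond the scatter, is therefore expected for compound 4 in this assay, about a 5.5-fold higher number from compound 1 to compound 4 (0.74 log units; beyond the scatter). Compound 4 is estimated at 55 nM, within a range from 18 nM to 170 nM.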

Compound 4, half-maximal inhibitory concentration: 150 nM
Compound 4: middle estimate off by 2.7-fold (0.44 log units), on the low side, within the range that was stated.
By their numbers in this assay, from the lowest: compounds 2 and 1 (each within the scatter of the next); then compound 3; then compound 4.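

In this assay, the 3-hydroxypiperidin-1-yl group on the sulfonyl sulfur gives a 15-fold higher number from compound 1 to compound 4 (1.18 log units; beyond the scatter) and a 20-fold higher number from compound 2 to compound 4 (1.31 log units; beyond the scatter) as large steps, which leaves compound 4 the weakest inhibitor of the four. Even against morpholin-4-yl, another six-membered non-aromatic ring on the same sulfur, there is a 2.2-fold higher number from compound 3 to compound 4 (0.34 log units; beyond the scatter) and this shows that the position can separate two rings of the same size, not just aromatic groups from non-aromatic ones; compound 2, which also carries a non-aromatic ring, goes against any rule that such rings always raise the number. Nothing available explains why these groups differ in this way.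

The compounds shown leave open whether the rise belongs to the hydroxyl or to the piperidine ring that carries it, a question that plain piperidin-1-yl, with no hydroxyl, would address directly. They also leave open whether the mirror-image form of 3-hydroxypiperidin-1-yl or the isomeric 4-hydroxypiperidin-1-yl would behave like compound 4 in this assay.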